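A few compounds are considered here, and "the series" means these few. Any claim that something is new, unique, unknown or untested is made for them only; others in the source may bear on it.

Compound 1 `COc1ccc(-c2cc3nccc(-c4cc(OC)c(OC)c(OC)c4)n3n2)cc1[N+](=O)[O-]`: > 10000 nM
Compound 2 `COc1cc(-c2ccnc3cc(-c4ccc5ccn(C)c5c4)nn23)cc(OC)c1OC`: 657 nM

In a functional assay on B16-F0 cells (Mus musculus) for inhibition, read by CCK-8 assay, with a stated time of 48 h (on this read-out higher numbers stand for weaker inhibition and lower numbers for stronger inhibition), compound 1 reaches only a limit of the assay, > 10000 nM. Compound 2 gives 657 nM in this assay, the only number shown. Compound 3 `COc1cc(-c2ccnc3cc(-c4ccc(F)cc4)nn23)cc(OC)c1OC` has not yet been measured. It differs from compound 2 in one place: 4-fluorophenyl in place of 1-methyl-1H-indol-6-yl on an aromatic carbon. Among the compounds with values here, no measured pair shows a change of this kind, so its size is open; a step beyond the usual scatter toward weaker inhibition is expected, a 3.0-fold higher number from compound 2 to compound 3 (0.48 log units; beyond the scatter). Compound 3 is therefore estimated at 2000 nM, between 600 nM and 8000 nM.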

Compound 3, half-maximal inhibitory concentration: 4540 nM
Compound 3: middle estimate off by 2.3-fold (0.36 log units), on the low side; the range from low to high includes it.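

In this assay putting 4-fluorophenyl in place of 1-methyl-1H-indol-6-yl on this aromatic carbon gives a 6.9-fold higher number from compound 2 to compound 3 (0.84 log units; beyond the scatter) and so shows that inhibition depends on the group held at this position. In this single pair, the two-ring group goes with the stronger inhibition. Nothing measured here accounts for the size of this step.

Because the two groups differ in several ways at once, this pair cannot show which difference matters. From the compounds shown here alone, how an unsubstituted phenyl, a pyridine or an indol-6-yl without the methyl would behave at this carbon remains open.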